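A few compounds are considered here, and "the series" means these few. Any claim that something is new, unique, unknown or untested is made for them only; others in the source may bear on it.

Values so far in a functional assay on SW 1116 cells (Homo sapiens) for antiproliferative activity, read by MTT assay, with a stated time of 48 h; a lower number here means a stronger inhibitor, a higher number a weaker inhibitor:
compound 1 `Fc1cccc(F)c1CSc1nnc(-c2cnccn2)o1`: 23800 nM
compound 2 `Brc1ccc(CSc2nnc(-c3cnccn3)s2)cc1`: 1470 nM
compound 3 `Clc1cccc(CSc2nnc(-c3cnccn3)n2-c2ccccc2)c1`: 6610 nM

In this assay compound 3, at 6610 nM, holds the middle place of the three numbers, with a gap beyond the scatter on each side: the number of compound 1 is higher and that of compound 2 is lower. For the measured compounds named here, the three differ in the core as well as in the group on the sulfur, so no measured pair isolates a single change.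

Next is the unmeasured compound 4 `Fc1cccc(F)c1CSc1nnc(-c2cnccn2)n1-c1ccccc1`, which keeps the core of compound 3. The change is 2,6-difluorophenyl in place of 3-chlorophenyl on a saturated chain carbon bound to a sulfur. Going by the values given here, the only measured compound carrying the 2,6-difluorobenzyl group is compound 1 at 23800 nM, on a different core, so it offers only a weak pointer toward a higher number. A modest move toward weaker inhibition is therefore expected, small enough that it may not clear the scatter. The expected shift is a 1.5-fold higher number from compound 3 to compound 4 (0.18 log units; within the scatter). Compound 4 is estimated at 10000 nM, with an expected range from 4000 nM to 25000 nM.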

Compound 4, half-maximal inhibitory concentration: 24100 nM
Compound 4: middle estimate off by 2.4-fold (0.38 log units), on the low side; measured number inside the range.
By their numbers in this assay, from the lowest: compound 2; then compound 3; then compounds 1 and 4 (each within the scatter of the next).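

In this assay, for the compounds shown here, the step from 3-chlorophenyl to 2,6-difluorophenyl on a saturated chain carbon bound to a sulfur gives a 3.6-fold higher number from compound 3 to compound 4 (0.56 log units; beyond the scatter), the first reading of a single change, and it shows that the number responds to the aryl group at this place while the core stays fixed. Compound 1 at 23800 nM and compound 4 at 24100 nM both carry the 2,6-difluorobenzyl group on different cores and lie within the scatter of each other, which is a printed match between two compounds and no general rule about the core. No measurement at hand accounts for the size of this step.

As far as these compounds go, this single step cannot separate the loss of the chlorine from the entry of the two fluorines, so the contribution of each remains open. Also open, from the compounds shown here alone, is how an unsubstituted benzyl, a methoxybenzyl or a longer chain such as phenethyl on the sulfur would read on the core of compound 3, and whether the 4-bromobenzyl group of compound 2, at 1470 nM on its own core, would carry over to that core.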